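Dichlorophenyl Isomers on the Ring Nitrogen, All Level in This Assay

The source may hold more compounds than are shown below. What is called first, only, known or untested is meant among the compounds shown, and "the series" means these compounds.

Compound 1, `CC(C)N1CCN(Cc2csc(N)c2C(=O)c2ccc(Cl)cc2)CC1`: 0%
Compound 2, `Nc1scc(CN2CCN(c3ccc(Cl)cc3Cl)CC2)c1C(=O)c1ccc(Cl)cc1`: 0%
Compound 3, `Nc1scc(CN2CCN(c3cccc(Cl)c3Cl)CC2)c1C(=O)c1ccc(Cl)cc1`: 0%

Of the compounds shown here, three sharing one core have been tested in an assay on CHO cells for displacement of a labelled ligand from adenosine receptor A3 (Homo sapiens), read by scintillation counting, with a stated time of 120 min, tested at 10 uM; on this read-out lower numbers stand for less inhibition and higher numbers for more inhibition at the one concentration tested (going by the name of the read-out). Compound 1 gives 0%, compound 2 gives 0%, and compound 3 gives 0%. Compound 3 stands level with both of the others: the step of no change at the digits printed from compound 1 to compound 3 (within the scatter) and the step of no change at the digits printed from compound 2 to compound 3 (within the scatter) are both within the scatter, as is the step of no change at the digits printed from compound 1 to compound 2 (within the scatter). Nothing in this set rises above the floor of this assay.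

Compound 4, `Nc1scc(CN2CCN(c3cc(Cl)cc(Cl)c3)CC2)c1C(=O)c1ccc(Cl)cc1`, is the next compound and differs from compound 3 by 3,5-dichlorophenyl in place of 2,3-dichlorophenyl on an amine nitrogen in a ring. Among the measured compounds shown here, the step that bears most directly on it is the one from compound 2 to compound 3, where one dichlorophenyl isomer replaced another on the ring nitrogen and the read-out did not move: no change at the digits printed from compound 2 to compound 3 (within the scatter). The steps from compound 1 show that even exchanging isopropyl for a dichlorophenyl left the read-out unchanged.

On that basis no step beyond the scatter is expected in this assay, so the step of no change at the digits printed from compound 3 to compound 4 (within the scatter) is estimated to be flat. Compound 4 is expected to give about 0%, within a range from -5% to 10%.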

Compound 4, a percentage reported as inhibition, at one concentration (the size of the read-out at that concentration, not a potency): 1%
Compound 4: the middle estimate sits 1 percentage points below what was measured, and the stated range covers the measured number.
By their numbers in this assay, from the lowest: compounds 1, 2, 3 and 4 (each within the scatter of the next).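

With compound 4, a third dichlorophenyl isomer on the ring nitrogen has been read in this assay: 3,5-dichlorophenyl in place of 2,3-dichlorophenyl gives a number 1 percentage points higher from compound 3 to compound 4 (within the scatter), and 3,5-dichlorophenyl in place of 2,4-dichlorophenyl gives a number 1 percentage points higher from compound 2 to compound 4 (within the scatter). The comparison with isopropyl is equally flat, with a number 1 percentage points higher from compound 1 to compound 4 (within the scatter), so across these compounds neither the arrangement of the two chlorines on the phenyl ring nor the exchange of isopropyl for dichlorophenyl lifts the read-out off the floor of this assay at the one concentration tested. No measurement at hand offers an explanation for this flat result.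

The compounds shown leave open whether any group on this ring nitrogen can raise the read-out in this assay, for example an unsubstituted phenyl, a benzyl, a pyridine or a carboxylic acid on a longer chain. They also leave open whether the dichlorophenyl isomers differ at all, since four readings at the floor cannot separate them, and whether a change elsewhere on the shared core, such as replacing the chlorine on the benzoyl ring with methoxy, would matter more.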